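Moving the Fluorine on the Pyridyl Alcohol of Compound 1

The source may hold more compounds than are shown below. What is called first, only, known or untested is meant among the compounds shown, and "the series" means these compounds.

The measured compounds:
Compound 1, `OC(c1ccc(F)cn1)C1(c2ccc(Cl)c(Cl)c2)CCC1`, gives 3170 mL/min/kg.
Compound 2, `C[C@]1(O)C[C@](c2ccnc(C(F)(F)F)c2)([C@H](O)c2ccccn2)C1`, gives 83.3 mL/min/kg.
Compound 3, `C[C@]1(O)C[C@@](c2ccc(OC(F)(F)F)cc2)([C@H](O)c2ccccn2)C1`, gives 133 mL/min/kg.

All three were read in an ADME assay on liver for metabolic stability, with Liver microsome (Rattus norvegicus) as the target, read by LC-MS, using microsomes, with a stated time of 5 h; on this read-out higher numbers stand for fast clearance and lower numbers for slow clearance. Compound 1 stands at the top of these three numbers: the gap from compound 1 down to compound 3 is beyond the scatter, and the gap from compound 1 down to compound 2 is wider still, also beyond the scatter. Compounds 2 and 3 share a different core from compound 1, so their values can only be set beside it, not joined to it by a single step.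

The unmeasured compound 4, `OC(c1ncccc1F)C1(c2ccc(Cl)c(Cl)c2)CCC1`, keeps every atom of compound 1 and differs from it only in how they are joined:
3-fluoropyridin-2-yl in place of 5-fluoropyridin-2-yl on a saturated chain carbon bound to an oxygen on a saturated carbon and a saturated ring carbon

Among the compounds with values here, no step between two measured compounds tells how such a rearrangement plays out in this assay, so the expectation rests on the fact that compound 4 is built from the same atoms as compound 1 and keeps its core and its chlorinated aryl group intact. Compound 4 is expected to give about 2600 mL/min/kg, within a range of 1000 mL/min/kg to 6500 mL/min/kg. The step of a 1.2-fold lower number from compound 1 to compound 4 (0.09 log units; within the scatter) is therefore estimated to stay within the scatter, with no direction that can be called out.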

Compound 4, clearance: 3000 mL/min/kg
For compound 4 the middle estimate is 1.2-fold (0.06 log units) below the measured one, within the range that was stated.
By their numbers in this assay, from the lowest: compounds 2 and 3 (each within the scatter of the next); then compounds 4 and 1 (each within the scatter of the next).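

In this assay, within the data shown here, the exchange of 5-fluoropyridin-2-yl for 3-fluoropyridin-2-yl gives a 1.1-fold lower number from compound 1 to compound 4 (0.02 log units; within the scatter), the first comparison in this set in which only one place differs. It shows that, with the core of compound 1 and its dichlorinated aryl group held fixed, these two fluorine placements on the pyridyl ring cannot be told apart in this read-out, and compound 4, at 3000 mL/min/kg, keeps a clearance of the same order as its parent. The account can offer no measured property that explains why the two arrangements read alike.

What the compounds shown leave open is whether the pyridyl ring responds to anything other than a shift of its fluorine, such as a nitrile or a methoxy group in its place, or whether the clearance of this series follows another part of the molecule, such as an amine in place of the hydroxyl group on the saturated chain carbon. They also leave open whether the same fluorine exchange would read alike on the different core of compound 2 and compound 3, whose pyridyl ring carries no fluorine at all.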